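The source may hold more compounds than are shown below. What is called first, only, known or untested is meant among the compounds shown, and "the series" means these compounds.

Compound 1 `COc1ccc(Br)cc1CCc1c(F)cccc1C(=O)/N=C(\N)NCCN1CCCC1` gives 4500 nM in a functional assay for antagonist activity at Melanocortin receptor 4 (Homo sapiens), read by cAMP accumulation; a lower number here means a stronger inhibitor, a higher number a weaker inhibitor.
Compound 2 `CCN(CC)CCCC(C)/N=C(\NC(=O)c1cccc(F)c1CCc1cc(Br)ccc1OC)Nc1ccccc1` gives "not determined" (no result reported) in this assay.

Going by the values given here, compound 1 is the only compound here with a measured number, so there is nothing to rank it against; compound 2 gives no value. Compound 3 `COc1ccc(Br)cc1CCc1c(F)cccc1C(=O)/N=C(\N)NCCCCN(C)Cc1ccccc1` differs from compound 1 by 2-(benzyl(methyl)amino)ethyl in place of pyrrolidin-1-yl on a saturated chain carbon, two bonds along the chain from an amine nitrogen. Among the compounds with values here, no step between measured compounds is available for this change, so the direction is uncertain; a shift within or just beyond the usual scatter is expected. The step from compound 1 to compound 3 is expected to be a 1.5-fold lower number from compound 1 to compound 3 (0.18 log units; within the scatter). Compound 3 is estimated at 3000 nM, within 800 nM to 12000 nM.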

Compound 3, half-maximal inhibitory concentration: 180 nM
Estimate against measurement, compound 3: 17-fold (1.22 log units) above; measured number outside the range, below it.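

In this assay, the place on a saturated chain carbon, two bonds along the chain from an amine nitrogen, proves sensitive to the group it carries, as the swap of pyrrolidin-1-yl for 2-(benzyl(methyl)amino)ethyl gives a 25-fold lower number from compound 1 to compound 3 (1.40 log units; beyond the scatter). The entering group adds a six-membered aromatic ring of carbon only, and the step lies beyond the scatter. Nothing measured here explains the shift. The compounds shown do not separate the contribution of the benzyl ring from that of the chain. A dimethylamino group on the same chain would bear on that question.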